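Series notes: methanesulfonamido added to the phenyl of compound 3

A few compounds are considered here, and "the series" means these few. Any claim that something is new, unique, unknown or untested is made for them only; others in the source may bear on it.

Compound 3 `CC(C)(N)C(=O)N[C@H](COCc1ccccc1)c1nnn(Cc2ccccc2)n1` gives 1120 nM in a functional assay on H4 cells for agonist activity at growth hormone secretagogue receptor type 1 (Homo sapiens), read by FLIPR (a higher number here means that more compound is needed for the effect, a lower number that less compound is needed), the highest number of the three measured compounds; compound 1 `CC(C)(N)C(=O)N[C@H](COCc1ccccc1)c1nnnn1Cc1ccc(NS(C)(=O)=O)cc1` gives 259 nM and compound 2 `CC(C)(N)C(=O)N[C@H](COCc1ccccc1)c1nnnn1CC#N` gives 29 nM. Compound 4 `CC(C)(N)C(=O)N[C@H](COCc1ccccc1)c1nnn(Cc2ccccc2NS(C)(=O)=O)n1` differs from compound 3 by methanesulfonamido in place of hydrogen on an aromatic carbon. For the measured compounds named here, the only measured single-place step, an 8.9-fold lower number from compound 1 to compound 2 (0.95 log units; beyond the scatter), runs the other way: removing the 4-(methanesulfonamido)phenyl in favour of cyano lowers the number, on a core substituted differently from compound 3, so by that step alone adding methanesulfonamido should raise the number. Yet compound 1, which carries the methanesulfonamido-bearing phenyl, stands below compound 3, and no single-place step connects compound 1 and compound 3. The step of a 1.4-fold lower number from compound 3 to compound 4 (0.15 log units; within the scatter) is therefore expected to be small and uncertain in direction. Compound 4 is estimated at 800 nM, with a range of 250 nM to 2500 nM.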

Compound 4, half-maximal effective concentration: 426 nM
Compound 4: middle estimate off by 1.9-fold (0.27 log units), on the high side, within the range that was stated.
By their numbers in this assay, from the lowest: compound 2; then compounds 1 and 4 (each within the scatter of the next); then compound 3.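

In this assay, methanesulfonamido in place of hydrogen on an aromatic carbon, ortho to a large group, gives a 2.6-fold lower number from compound 3 to compound 4 (0.42 log units; beyond the scatter) on this phenyl. This step reads the group alone, whereas an 8.9-fold lower number from compound 1 to compound 2 (0.95 log units; beyond the scatter) exchanged the whole 4-(methanesulfonamido)phenyl for cyano and could not separate the group from its phenyl. No evidence on the origin of this step is at hand.

The compounds shown leave open whether an amine or a carboxylic acid on the same aromatic carbon gives a step of like size. On these data alone, whether the methanesulfonamido step carries over to the core of compound 1 also stays open.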